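The source may hold more compounds than are shown below. What is called first, only, known or untested is meant among the compounds shown, and "the series" means these compounds.

The study gathers four hydrazone-linked thiosemicarbazides and ureas on related bicyclic cores. Compound 1 `CN(C)C(=S)N/N=C/c1cc2cccnc2s1` carries a dimethyl thiosemicarbazide on its core, and in a functional assay on HT-29 cells (Homo sapiens) for antiproliferative activity, read by sulforhodamine B assay, with a stated time of 72 h (on this read-out lower numbers stand for stronger inhibition and higher numbers for weaker inhibition), compound 1 gives 13400 nM. Compound 2 `Fc1ccccc1NC(=S)N/N=C/c1ccc2ccccc2n1` pairs a 2-fluorophenyl thiosemicarbazide with a different core. In this assay compound 2 gives only a limit, > 100000 nM, and no number. Compound 3 `Cc1ccc(NC(=O)N/N=C/c2ccc3ccccc3n2)cc1` carries a 4-methylphenyl urea on the same core as compound 2. In this assay compound 3 likewise gives only a limit, > 100000 nM. Thus compound 2 sits at the limit of > 100000 nM in this assay, at which 2 of the 3 values shown sit, while compound 1 alone returns a measured concentration; no step between two measured compounds can be counted here.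

Compound 4 `S=C(N/N=C/c1ccc2ccccc2n1)Nc1ccccc1` is the unmeasured analogue of compound 2, obtained through (hydrogen in place of fluoro on an aromatic carbon), that is, from 2-fluorophenyl to phenyl. For the measured compounds named here, with no measured step available, the size of the change in this assay is expected to lie within the usual scatter, in no firm direction; a loss of a single fluorine is not expected to turn compound 2 into an active compound. Compound 4 is therefore estimated at 120000 nM, between 30000 nM and 400000 nM, with the step that the limit leaves unreadable from compound 2 to compound 4 expected to be modest, most probably ending in another limit.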

Compound 4, half-maximal inhibitory concentration: 17000 nM
Compound 4: middle estimate off by 7.1-fold (0.85 log units), on the high side; measured number outside the range, below it.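

In this assay, for the compounds shown here, exchanging fluoro for hydrogen on an aromatic carbon of the six-membered aromatic ring, ortho to a large group, gives an at least 5.8-fold lower number from compound 2 to compound 4 (0.76 log units; beyond the scatter), the first step that can be read in this set. Going by these compounds alone, this shows that this one position is not indifferent on this core: losing a single fluorine, with no ring, donor, acceptor or charge changing, separates a compound held at a limit from one that returns a measured concentration, which no earlier compound on this core had done. The true size of the step remains unknown, and the printed figure is only its smallest possible size, because compound 2 is held at a limit rather than a number: the limit of > 100000 nM in this assay, at which 2 of the 4 values shown sit.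

The compounds shown leave open whether a chlorine atom, a methyl group or a methoxy group on the same aromatic carbon would track with the fluoro of compound 2 or with the hydrogen of compound 4. They also leave open whether the same exchange would have a comparable effect in a urea series, where the only compound shown, compound 3, sits at its own limit of > 100000 nM.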